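The compounds below may be only part of what the source reports. "The series", "measured", "known", "first", "only" and "open" are said of these compounds alone.

Compound 1, `COc1cc(N)c(Cl)cc1C(=O)NC1CCN(CCCCCCCCO)CC1`, is the reference point here. In a functional assay on HEK293 cells for activation of 5-hydroxytryptamine receptor 4 (Homo sapiens), read by cAMP accumulation (a higher number here means a larger maximal response, a lower number a smaller maximal response), compound 1 gives > 100%, which is a limit of the assay and not a number. Compound 1 therefore sits at the limit of > 100% in this assay, at which 2 of the 3 values shown sit, so its exact standing cannot be read. Compound 2, `COc1cc(N)c(Cl)cc1C(=O)NC1CCN(CCCCCCCCN2C(=O)c3ccccc3C2=O)CC1`, gives 89% in this assay. Compound 3, `COc1cc(N)c(Cl)cc1C(=O)NC1CCN(CCN2CCCCC2)CC1`, gives > 100% in this assay, again a limit of the assay.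

Two measured steps start from compound 1. The step of a number at least 11 percentage points lower from compound 1 to compound 2 (beyond the scatter) goes with a large ring-bearing group replacing a hydroxyl far out on the chain. The step that the two limits leave unreadable from compound 1 to compound 3 goes with a saturated nitrogen ring replacing a hydroxyl-ended chain close to the ring nitrogen.

Compound 4, `COc1cc(N)c(Cl)cc1C(=O)NC1CCN(CCCCCN2CCN(S(C)(=O)=O)CC2)CC1`, has not yet been measured. The change from compound 1 is 4-(methylsulfonyl)piperazin-1-yl in place of 3-hydroxypropyl on a saturated chain carbon, five bonds along the chain from an amine nitrogen in a ring. Going by the values given here, of the two known steps, the one to compound 2 is the nearer analogue: a hydroxyl end gives way to a larger group carrying a ring, and the maximal response fell at least modestly. The step to compound 3 is unreadable and gives no direction. He therefore expects a modest drop, a number at least 12 percentage points lower from compound 1 to compound 4 (beyond the scatter), in this assay. Compound 4 is estimated to reach 88%, within 72% to 104%.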

Compound 4, intrinsic activity: the largest response reached, in percent of the reference agonist's: > 100%
Compound 4 was reported as a limit (the forecaster's own chance of this, stated with the estimate: 25%); at least 12 percentage points between middle value and limit.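

In this assay compound 4 gives > 100%, which is a limit of the assay and not a number. No new step can be read from compound 1 to compound 4, because both compounds stand at a limit: the limit of > 100% in this assay, at which 3 of the 4 values shown sit.

The compounds shown leave open what the actual maximal responses of compound 1, compound 3 and compound 4 are, and whether 4-(methylsulfonyl)piperazin-1-yl in place of 3-hydroxypropyl changes the response at all.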